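Chloro to methoxy on the benzoyl ester of compound 3

The source may hold more compounds than are shown below. What is called first, only, known or untested is meant among the compounds shown, and "the series" means these compounds.

Measured so far in a functional assay on HT-29 cells (Homo sapiens) for antiproliferative activity, read by MTT assay, with a stated time of 48 h; a lower number here means a stronger inhibitor, a higher number a weaker inhibitor:
compound 1 `O=C(Nc1ccc(OC(=O)c2cc3cc([N+](=O)[O-])ccc3s2)cc1)Nc1ccc(Oc2ccccc2)cc1` gives 13300 nM
compound 2 `CC(=O)c1cccc(NC(=O)Nc2ccc(OC(=O)c3cc4cc([N+](=O)[O-])ccc4s3)cc2)c1` gives 457000 nM
compound 3 `O=C(Nc1ccc(OC(=O)c2ccc(Cl)cc2)cc1)Nc1ccc(Cl)c(C(F)(F)F)c1` gives 8320 nM

Compound 3 has the lowest of the three numbers in this assay. Its nearest neighbour is compound 1, whose number is higher by an amount within the scatter, so the two cannot be told apart; compound 2 lies far beyond the scatter above both.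

The next compound, compound 4 `COc1ccc(C(=O)Oc2ccc(NC(=O)Nc3ccc(Cl)c(C(F)(F)F)c3)cc2)cc1`, differs from compound 3 in one place: methoxy in place of chloro on an aromatic carbon. Among the measured compounds shown here, no measured pair carries the same change, so the step is open. The change is small and sits on the ester end of the molecule, away from the urea that compounds 1 to 3 share. For compound 4 the step of a 1.3-fold higher number from compound 3 to compound 4 (0.12 log units; within the scatter) is expected to be modest, most likely a slight rise in the number or none beyond the scatter. Compound 4 is therefore estimated at 11000 nM in this assay, with a range from 3500 nM to 35000 nM.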

Compound 4, half-maximal inhibitory concentration: 33800 nM
Estimate against measurement, compound 4: 3.1-fold (0.49 log units) below, and the stated range covers the measured number.
By their numbers in this assay, from the lowest: compounds 3 and 1 (each within the scatter of the next); then compound 4; then compound 2.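

In this assay, the change from 4-chlorophenyl to 4-methoxyphenyl at the ester end gives a 4.1-fold higher number from compound 3 to compound 4 (0.61 log units; beyond the scatter), so this place, para to a large group, responds to a single substitution. Among the compounds shown here, this is the first step that changes one place with the rest of the molecule held fixed, and it shows that chloro gives the lower number of the two groups on this scaffold. Nothing at hand accounts for the rise in the number.

A single pair cannot separate the effect of losing chloro from that of gaining methoxy, so a hydrogen, fluoro, methyl, hydroxy or amine at this place would be needed to show which matters. On these data alone, whether the same step holds with the other urea partners, as in compound 1 and compound 2, remains open.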